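The compounds below may be only part of what the source reports. "The series", "measured", "known", "first", "only" and "open" are said of these compounds alone.

Going by the values given here, compound 1 `CC(=O)N1CC2CC(C1)N2` carries an acetyl on the shared core and in an assay on SH-EP1 cells for agonist activity at Neuronal acetylcholine receptor; alpha4/beta2 (Homo sapiens), read by FLIPR and calcium flux (on this read-out higher numbers stand for an effect only at larger amounts of compound and lower numbers for an effect already at smaller amounts), compound 1 gives 9700 nM, the highest of the two numbers so far. Compound 2 `CCC(=O)N1CC2CC(C1)N2` gives 5900 nM; the step of a 1.6-fold lower number from compound 1 to compound 2 (0.22 log units; within the scatter) is the only measured one and stays within the scatter. Compound 3 `O=C(C1CCC1)N1CC2CC(C1)N2` differs from compound 1 by cyclobutyl in place of methyl on a carbonyl carbon. Among the compounds with values here, the single measured step points, if anywhere, to a lower number with a larger acyl group, so for compound 3 a modest step of a 2.4-fold lower number from compound 1 to compound 3 (0.38 log units; beyond the scatter) is expected. The estimate for compound 3 is 4000 nM, with a range of 1500 nM to 15000 nM.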

Compound 3, half-maximal effective concentration: 11000 nM
Estimate against measurement, compound 3: 2.8-fold (0.44 log units) below, and the stated range covers the measured number.
By their numbers in this assay, from the lowest: compounds 2, 1 and 3 (each within the scatter of the next).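

In this assay, cyclobutyl on the carbonyl carbon, with its four-membered ring, leaves the number within the scatter of both smaller groups (a 1.1-fold higher number from compound 1 to compound 3 (0.05 log units; within the scatter); a 1.9-fold higher number from compound 2 to compound 3 (0.27 log units; within the scatter)). The lower number hinted at for a larger acyl group in the first step therefore does not extend to compound 3, and compound 1, compound 2 and compound 3 cannot be ordered. No evidence at hand bears on this result.

On these data alone, whether a phenyl ring, an amine or a carboxylic acid at this carbonyl carbon would move the number beyond the scatter stays open.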